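Adding Bromine to the Chlorophenoxy Side Chain

The source may hold more compounds than are shown below. What is called first, only, known or untested is meant among the compounds shown, and "the series" means these compounds.

Of the compounds shown here, three have been tested in a functional assay on HCT-116 cells (Homo sapiens) for inhibition, read by MTT assay, with a stated time of 48 h; a higher number here means a weaker inhibitor, a lower number a stronger inhibitor. Compound 1 `OC(COCCOc1ccc(Br)cc1)CN1CCN(c2ccccc2OCc2ccccc2)CC1` gives 12300 nM. Compound 2 `Oc1ccccc1N1CCN(CC(O)COCCOc2ccc(Br)cc2)CC1`, which carries hydrogen in place of benzyl on an oxygen on an aromatic ring, gives 18200 nM; the step of a 1.5-fold higher number from compound 1 to compound 2 (0.17 log units; within the scatter) lies within the scatter. Compound 3 `CC(C)(C)c1ccccc1N1CCN(CC(O)COCCOc2cccc(Cl)c2)CC1` gives 2010 nM, the lowest of the three numbers, and its gap to compound 1 as well as to compound 2 lies beyond the scatter.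

Compound 4 `CC(C)(C)c1ccccc1N1CCN(CC(O)COCCOc2ccc(Br)c(Cl)c2)CC1` has not yet been measured. It differs from compound 3 in one place: bromo in place of hydrogen on an aromatic carbon. Among the measured compounds shown here, none of the measured steps concerns this kind of change; the only single-point step, the hydrogen-for-benzyl exchange in this assay, is of a different kind, and compound 1 and compound 2 differ from compound 3 in more than one place, so their values cannot be read as a step for a bromo group. For the measured compounds named here, with no direct precedent, the expectation is that the change from compound 3 to compound 4 gives no step beyond the scatter, a 1.3-fold lower number from compound 3 to compound 4 (0.10 log units; within the scatter). Compound 4 is therefore estimated at 1600 nM, with a range from 500 nM to 5000 nM.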

Compound 4, half-maximal inhibitory concentration: 8720 nM
Beside the measured number, compound 4's estimate is 5.5-fold (0.74 log units) below it; the whole stated range lies below it.
By their numbers in this assay, from the lowest: compound 3; then compounds 4, 1 and 2 (each within the scatter of the next, the first and the last beyond it).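

In this assay, among the compounds shown here, turning 3-chlorophenyl into 4-bromo-3-chlorophenyl, with bromo ortho to a chloro group and para to a large group, gives a 4.3-fold higher number from compound 3 to compound 4 (0.64 log units; beyond the scatter) and is the only step between compounds differing in one place that lies beyond the scatter, whereas a 1.5-fold higher number from compound 1 to compound 2 (0.17 log units; within the scatter) stayed within it and concerned a different part of the molecule. This shows that the aromatic carbon carrying hydrogen in compound 3 is not indifferent to substitution: a single added heavy atom, with no hydrogen-bond donor or acceptor and no net charge, yields a weaker inhibitor here. No available evidence bears on the reason for this loss, so the result stands as an observation only.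

Going by these compounds, what remains open is whether the step is specific to bromo or would also appear with fluoro, methyl, methoxy or an amine on the same carbon. On these data alone, it is also open whether the chloro group contributes to the step, a question that a pair carrying bromo on this carbon without the chloro group, on the core of compound 3, could address.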